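The source may hold more compounds than are shown below. What is called first, only, known or untested is meant among the compounds shown, and "the series" means these compounds.

Compound 1 `CCOC(=O)c1nn(-c2ccccc2)c(-c2ccc(Cl)cc2)c1CNC(C)(C)C`: 28600 nM; > 559000 nM (2 entries)
Compound 2 `CCOC(=O)c1nn(-c2ccc(Cl)cc2)c(-c2ccc(C)cc2)c1CNC(C)(C)C`: 249000 nM; > 542000 nM (2 entries)
Compound 3 `CC(C)(C)NCc1c(C(=O)O)nn(-c2ccccc2)c1-c1ccc(Cl)cc1`: 145000 nM

All of these come from a functional assay on PC-3 cells (Homo sapiens) for inhibition, read by sulforhodamine B assay, with a stated time of 48 h; on this read-out higher numbers stand for weaker inhibition of growth and lower numbers for stronger inhibition of growth. Compound 1 gives 28600 nM; > 559000 nM (2 entries). For compound 1 the entry with a sign is a limit of this assay, not a number. Compound 2 gives 249000 nM; > 542000 nM (2 entries). For compound 2 too the entry with a sign is a limit. Among the measured compounds shown here, compound 3, at 145000 nM, is the only compound with a single number, so it is the firmest reference point available.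

Compound 4 `Cc1ccc(-c2c(CNC(C)(C)C)c(C(=O)O)nn2-c2ccccc2)cc1` differs from compound 3 in one place: methyl in place of chloro on an aromatic carbon. The 4-chlorophenyl group becomes 4-methylphenyl. For the measured compounds named here, no measured pair of compounds shows this change on its own. The expectation therefore starts from compound 3 at 145000 nM, with no shift beyond the scatter in this assay. The expected 1.0-fold higher number from compound 3 to compound 4 (0.01 log units; within the scatter) is small and its direction is open. For compound 4 the estimated value is 150000 nM, with an expected range of 60000 nM to 400000 nM.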

Compound 4, concentration for 50% growth inhibition: > 688000 nM
Compound 4 gave a limit, no number; the forecaster's own chance of this, stated with the estimate: 30%; at least 4.5-fold (0.66 log units) between middle value and limit.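

In this assay, among the compounds shown here, going from 4-chlorophenyl to 4-methylphenyl gives an at least 4.7-fold higher number from compound 3 to compound 4 (0.67 log units; beyond the scatter), a direct comparison at this position that the earlier compounds did not offer. It shows that methyl does not stand in for chloro here without a loss of growth inhibition. The figure for compound 4 is a limit of the assay, not a number, so the true size of the loss stays unknown and the step gives only its smallest size: the limit of > 688000 nM in this assay, at which 1 of the 4 values shown sits.

As far as these compounds go, whether a fluoro or a methoxy group in place of chloro would keep the growth inhibition of compound 3 remains open. Also open is whether the same change would act alike with the ethyl ester of compound 1, which has no single figure to start from: the several entries of compound 1 in this assay, 28600 nM; > 559000 nM (2 entries)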